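This account rests on a few compounds, and the source may have more. Where it says the series, first, only, none or still open, it means among the compounds named here.

Measured compounds:
- compound 1 `Clc1ccc(-c2cc(-c3cccs3)nc(-c3ccccc3Cl)c2)o1` – 18500 nM
- compound 2 `Cc1ccc(-c2cc(-c3ccoc3)cc(-c3ccsc3)n2)cc1` – 1470 nM
- compound 3 `Cc1ccc(-c2cc(-c3ccc(Cl)o3)cc(-c3ccsc3)n2)o1` – > 50000 nM

All three were tested in a functional assay on HeLa cells (Homo sapiens) for cytotoxicity, in the presence of a further agent that is not named here; a lower number here means a stronger inhibitor, a higher number a weaker inhibitor. Compound 1 shows the highest number among the two compounds that gave a number; compound 2 sits well below it, and the gap between them is beyond the usual scatter. Compound 3 gave no number at all in this assay: its result is only a limit, (the limit of > 50000 nM in this assay, at which 1 of the 3 values shown sits), meaning the assay could report nothing more exact.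

The unmeasured compound 4 `Clc1ccc(-c2cc(-c3ccc(Cl)o3)cc(-c3cccs3)n2)cc1` is built from the same atoms as compound 1, joined differently: 4-chlorophenyl in place of 2-chlorophenyl on an aromatic carbon. The chlorine on the phenyl ring thus moves to a different position while everything else in the shared core stays as it is. Among the compounds with values here, no pair of measured compounds shows this particular change, so its effect is not known from the data here. Since compound 1 itself already sits at a weak level with 18500 nM, compound 4 is expected to stay in a similar weak region, with the step from compound 1 to compound 4 estimated as a 1.2-fold lower number from compound 1 to compound 4 (0.09 log units; within the scatter), which is not expected to go beyond the scatter. The estimate for compound 4 in this assay is 15000 nM, in a range from 4000 nM to 50000 nM.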

Compound 4, half-maximal inhibitory concentration: 21300 nM
Compound 4: middle estimate off by 1.4-fold (0.15 log units), on the low side, and the stated range covers the measured number.
By their numbers in this assay, from the lowest: compound 2; then compounds 1 and 4 (each within the scatter of the next). At a limit, above all of these: compound 3.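

In this assay, putting 4-chlorophenyl in place of 2-chlorophenyl on the aromatic carbon next to the ring nitrogen gives a 1.2-fold higher number from compound 1 to compound 4 (0.06 log units; within the scatter). This is the first pair among the compounds shown that differs in only one place, and it shows that, with the rest of the shared core unchanged, these two chlorophenyl groups cannot be told apart at this position in this assay: moving the chlorine around the phenyl ring from the one placement to the other leaves the result at the same weak level. Nothing in the data shown offers an explanation for this lack of a difference.

Within the data shown here, whether a phenyl ring carrying an amine or a carboxylic acid at this position would give a clearly different number remains open, since the only change that can be read here is this shift of one chlorine. Compound 2, at 1470 nM, differs from both compound 1 and compound 4 in more than one place, so the compounds shown do not reveal which of its structural features goes with its number.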